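This account rests on a few compounds, and the source may have more. Where it says the series, first, only, none or still open, it means among the compounds named here.

In a functional assay on MDA-MB-231 cells (Homo sapiens) for antiproliferative activity, read by MTT assay, with a stated time of 24 h (a lower number here means a stronger inhibitor, a higher number a weaker inhibitor), compound 1 `COc1ccc(-c2noc(-c3ccccc3)n2)cc1OC1CCCC1` gives > 1000000 nM, which is a limit of the assay and not a number. Compound 2 `COc1ccc(-c2noc(C3CCNCC3)n2)cc1OC1CCCC1` gives 370 nM, and compound 3 `COc1ccc(-c2noc(-c3ccc(F)cc3)n2)cc1OC1CCCC1` gives 55500 nM, the higher of the two true numbers, with a 150-fold higher number from compound 2 to compound 3 (2.18 log units; beyond the scatter). Compound 4 `COc1ccc(-c2noc(-c3ccc(Cl)cc3)n2)cc1OC1CCCC1` differs from compound 3 by chloro in place of fluoro on an aromatic carbon, para to a large group. The closest measured change is fluoro in place of hydrogen at that place, a large step showing an at least 18-fold lower number from compound 1 to compound 3 (1.25 log units; beyond the scatter). Among the compounds with values here, no measured step swaps one halogen for another, so only a modest change is expected, with no firm direction. The estimate is a 1.2-fold lower number from compound 3 to compound 4 (0.09 log units; within the scatter). For compound 4 the expected value is 45000 nM, within an estimated range of 10000 nM to 200000 nM.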

Compound 4, half-maximal inhibitory concentration: 396000 nM
Compound 4: middle estimate off by 8.8-fold (0.94 log units), on the low side; measured number outside the range, above it.
By their numbers in this assay, from the lowest: compound 2; then compound 3; then compound 4. At a limit, above all of these: compound 1.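

Chloro in place of fluoro on this aromatic carbon, para to a large group, is not a neutral swap: it gives a 7.1-fold higher number from compound 3 to compound 4 (0.85 log units; beyond the scatter), the first halogen-for-halogen step in the series. Chloro in place of hydrogen still gives an at least 2.5-fold lower number from compound 1 to compound 4 (0.40 log units; beyond the scatter), while the piperidin-4-yl compound remains far ahead, with a 1100-fold higher number from compound 2 to compound 4 (3.03 log units; beyond the scatter). Compound 1 stands at a limit of the assay, so its step is a bound and not a true size: the limit of > 1000000 nM in this assay, at which 1 of the 4 values shown sits. Open, from the compounds shown here alone, is how bromo, methyl or an amine at this same place would compare with fluoro and chloro.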